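A few compounds are considered here, and "the series" means these few. Any claim that something is new, unique, unknown or untested is made for them only; others in the source may bear on it.

Measured compounds:
- Compound 1 `COC1=CC(=O)C(C)=C([S@@+]([O-])c2ccc(C)cc2)C1=O`: 8000 nM
- Compound 2 `CCS(=O)(=O)c1ccc(OC)c(Nc2ncc(-c3cc(-c4ccccn4)cc(-c4ccccn4)c3)o2)c1`: 2800 nM

In a functional assay on Huh-7 cells (Homo sapiens) for inhibition, read by sulforhodamine B assay, with a stated time of 72 h (on this read-out higher numbers stand for weaker inhibition and lower numbers for stronger inhibition), compound 1 gives 8000 nM, the highest of the two numbers. Compound 2 gives 2800 nM, and this gap lies beyond the usual scatter, so compound 1 is the weaker inhibitor of the pair.

Compound 3 `CCOC1=CC(=O)C(C)=C([S@@+]([O-])c2ccc(C)cc2)C1=O` has not yet been measured. It differs from compound 1 in a single place: methyl in place of hydrogen on a saturated chain carbon bound to an oxygen on an unsaturated carbon. This puts methyl in place of hydrogen on a saturated chain carbon bound to an oxygen on an unsaturated carbon, turning methoxy into ethoxy.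

Among the measured compounds shown here, no measured pair shows what this change does, and the change is small, so no shift beyond the scatter is expected in this assay. The estimated step is a 1.1-fold lower number from compound 1 to compound 3 (0.06 log units; within the scatter). For compound 3 the estimated value is 7000 nM, with an expected range from 3000 nM to 16000 nM.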

Compound 3, half-maximal inhibitory concentration: 7000 nM
Estimate against measurement, compound 3: no gap at the digits printed, within the range that was stated.
By their numbers in this assay, from the lowest: compound 2; then compounds 3 and 1 (each within the scatter of the next).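

Going from methoxy to ethoxy gives the first direct reading at this position: in this assay the change is a 1.1-fold lower number from compound 1 to compound 3 (0.06 log units; within the scatter) and so cannot be told apart from no change at all. The core of compound 1 therefore keeps its number in this assay when one methyl is added to this saturated chain carbon bound to an oxygen, a point that the unrelated compound 2 could not show. Nothing available explains why the number holds.

This single small step says little about larger changes at the same place, so a longer chain such as propyl or butyl remains an open question. An amine or a carboxylic acid carried on that chain could also behave quite differently from the ethoxy of compound 3.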